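Replacing nitro with hydrogen on compound 3

The compounds below may be only part of what the source reports. "The series", "measured", "known", "first", "only" and "open" are said of these compounds alone.

In a functional assay on HCT-116 cells (Homo sapiens) for antiproliferative activity, read by CCK-8 assay and cell counting, with a stated time of 72 h (on this read-out lower numbers stand for stronger inhibition and higher numbers for weaker inhibition), compound 3 `O=C(Nc1ccccc1)c1ccc(CO[N+](=O)[O-])cc1` gives 600 nM and stands level with compound 1 `O=C(Nc1ccccc1OC(=O)c1ccc(CCl)cc1)c1ccc(CCl)cc1` at 600 nM while compound 2 `O=C(Nc1ccccc1OC(=O)c1ccc(CO[N+](=O)[O-])cc1)c1ccc(CO[N+](=O)[O-])cc1` gives 700 nM and lies within the scatter of both. Compound 4 `O=C(Nc1ccccc1)c1ccc(CO)cc1` has hydrogen in place of nitro on an oxygen on a saturated carbon so that (nitrooxy)methyl becomes hydroxymethyl. Among the compounds with values here, all three measured compounds carry (nitrooxy)methyl or chloromethyl groups, and none carries hydroxymethyl, so no measured step guides this change. In this assay a step beyond the scatter toward a higher number, meaning weaker inhibition, is expected. The expected step of a 6.7-fold higher number from compound 3 to compound 4 (0.82 log units; beyond the scatter) is only an estimate. For compound 4 the estimated value is 4000 nM with an expected range of 700 nM to 30000 nM on this read-out.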

Compound 4, half-maximal inhibitory concentration: 24800 nM
Estimate against measurement, compound 4: 6.2-fold (0.79 log units) below, within the range that was stated.
By their numbers in this assay, from the lowest: compounds 1, 3 and 2 (each within the scatter of the next); then compound 4.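

In this assay, hydrogen in place of nitro on the oxygen gives a 41-fold higher number from compound 3 to compound 4 (1.62 log units; beyond the scatter), the first step measured at this place, so in this series inhibition depends strongly on whether (nitrooxy)methyl or hydroxymethyl stands there. The earlier compounds shown here offered no such step. Nothing shown accounts for its size.

Going by these compounds, it remains open whether other groups in this place would keep the inhibition of compound 3 or fall with compound 4. An aminomethyl or a carboxylic acid on the shared core would test this.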